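The compounds below may be only part of what the source reports. "The series", "measured", "known", "first", "only" and "open" are said of these compounds alone.

The shared core of these compounds, an urea carrying a trimethylphenyl group and a cycloheptyl ring, is held constant; what varies is the group hanging off the benzylic arm. In a functional assay on a cell-free system (plasma) with sterol O-acyltransferase, Soat (Rattus norvegicus) as the target (on this read-out lower numbers stand for an effect already at smaller amounts and higher numbers for an effect only at larger amounts of compound), compound 1, drawn as `Cc1cc(C)c(NC(=O)N(Cc2ccc(-c3ccccc3)o2)C2CCCCCC2)c(C)c1`, gives < 1 mg/kg, which is a limit of the assay rather than a number, as shown by the limit of < 1 mg/kg in this assay, at which 1 of the 2 values shown sits. Compound 2, drawn as `Cc1cc(C)c(NC(=O)N(Cc2ccc(-c3nnc(C)o3)cc2)C2CCCCCC2)c(C)c1`, gives > 0.32 mg/kg in this assay, again a limit rather than a number, as shown by the limit of > 0.32 mg/kg in this assay, at which 1 of the 2 values shown sits. So compound 2 stands only on one side of a boundary, and the two results are consistent with each other.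

Compound 3, drawn as `Cc1cc(C)c(NC(=O)N(Cc2ccc(-c3cn[nH]c3)cc2)C2CCCCCC2)c(C)c1`, differs from compound 2 in a single place: 1H-pyrazol-4-yl in place of 5-methyl-1,3,4-oxadiazol-2-yl on an aromatic carbon. Among the compounds with values here, no step between measured compounds is available to calibrate this change, so the expectation rests on the limit of compound 2 alone. The change is expected to be small, close to none beyond the usual scatter, and the step from compound 2 to compound 3 is estimated as a step that the limit leaves unreadable from compound 2 to compound 3. Compound 3 is therefore expected to give about 1 mg/kg in this assay, within a range from 0.3 mg/kg to 3 mg/kg.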

Compound 3, dose for half-maximal effect: > 1 mg/kg
Compound 3: a limit, no number (the forecaster's own chance of this, stated with the estimate: 40%); the middle value lies on the limit itself.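

In this assay, within the data shown here, compound 2 and compound 3 are each reported only as a limit, not as a number, and no step between them can be read. As far as these compounds go, it remains open how far apart their true values lie, and whether 1H-pyrazol-4-yl in place of 5-methyl-1,3,4-oxadiazol-2-yl changes the effect at all.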